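Swapping the dimethoxyphenyl group of compound 3

The compounds below may be only part of what the source reports. "The series", "measured", "known", "first", "only" and "open" are said of these compounds alone.

In a functional assay on PC-3 cells (Homo sapiens) for cytotoxicity, read by MTT assay, with a stated time of 48 h (a lower number here means a stronger inhibitor, a higher number a weaker inhibitor), compound 3 `COc1cccc(OC)c1/C=C/[C@](C)(O)CC[C@@H]1[C@@]2(C)CCCC(C)(C)[C@@H]2CC[C@@]1(C)O` is the weakest of the three measured compounds, at 4000 nM. Compound 1 `CC1(C)CCC[C@]2(C)[C@@H](CC[C@@](C)(O)/C=C/c3cccc([N+](=O)[O-])c3)[C@](C)(O)CC[C@@H]12` gives 153 nM and compound 2 `Cc1ccc(C)c(/C=C/[C@](C)(O)CC[C@@H]2[C@@]3(C)CCCC(C)(C)[C@@H]3CC[C@@]2(C)O)c1` gives 176 nM. Between these two lies only a 1.2-fold higher number from compound 1 to compound 2 (0.06 log units; within the scatter). Compound 4 `Cc1cccc(/C=C/[C@](C)(O)CC[C@@H]2[C@@]3(C)CCCC(C)(C)[C@@H]3CC[C@@]2(C)O)c1C` keeps the shared core and changes one group: 2,3-dimethylphenyl in place of 2,6-dimethoxyphenyl on a double-bonded chain carbon bound to a double-bonded chain carbon. Two measured steps lead to the 2,6-dimethoxyphenyl group, a 26-fold higher number from compound 1 to compound 3 (1.42 log units; beyond the scatter) and a 23-fold higher number from compound 2 to compound 3 (1.36 log units; beyond the scatter), and both are large. Compound 2, with its 2,5-dimethylphenyl group, is the closest guide, since it also carries a dimethylphenyl group. A large step back toward stronger inhibition is therefore expected in this assay, namely an 18-fold lower number from compound 3 to compound 4 (1.26 log units; beyond the scatter). Compound 4 is estimated at 220 nM, within an expected range of 70 nM to 800 nM.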

Compound 4, half-maximal inhibitory concentration: 3500 nM
Estimate against measurement, compound 4: 16-fold (1.20 log units) below; the whole stated range lies below it.
By their numbers in this assay, from the lowest: compounds 1 and 2 (each within the scatter of the next); then compounds 4 and 3 (each within the scatter of the next).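

In this assay, 2,3-dimethylphenyl in place of 2,6-dimethoxyphenyl gives a 1.1-fold lower number from compound 3 to compound 4 (0.06 log units; within the scatter) and so leaves the number in place, even though the oxygens are gone. Two dimethylphenyl groups can also differ widely here, with a 20-fold higher number from compound 2 to compound 4 (1.30 log units; beyond the scatter) for the change between them, and the 3-nitrophenyl group stands equally far off, with a 23-fold higher number from compound 1 to compound 4 (1.36 log units; beyond the scatter) as its step. Nothing measured here explains these gaps.

On these data alone, it remains open whether other placements of the two methyl groups, or an amine or a carboxylic acid on the phenyl ring, would give numbers like those of compound 1 and compound 2.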